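Removing the Second Acid Group: Compound 3 to Compound 4

The source may report more compounds than this note shows. Statements on the series, on what has been measured and on what is new or still open speak of the compounds shown alone.

Measured so far:
- compound 1 `C[C@@H](O)[C@H](NC(=O)CN(c1nc(Cl)nc2[nH]cnc12)C1CC1)C(=O)O`: 24%
- compound 2 `O=C(O)CC[C@H](NC(=O)CN(c1nc(Cl)nc2[nH]cnc12)C1CC1)C(=O)O`: 29.5%
- compound 3 `O=C(O)C[C@H](NC(=O)CN(c1nc(Cl)nc2[nH]cnc12)C1CC1)C(=O)O`: 11.6%

In a functional assay on the whole organism (Tail, strain ICR) with Mus musculus as the target, in the tail flick test, with a stated time of 150 min, at a dose of 25 umol/kg by the oral route (a higher number here means a stronger effect of the compound at the dose given, a lower number a weaker effect), compound 3 stands lowest of the three, with a number 17.9 percentage points lower from compound 2 to compound 3 (beyond the scatter) and a number 12.4 percentage points lower from compound 1 to compound 3 (beyond the scatter). Compound 4 `CSCC[C@H](NC(=O)CN(c1nc(Cl)nc2[nH]cnc12)C1CC1)C(=O)O` carries the change ((methylsulfanyl)methyl in place of carboxy on a saturated chain carbon, two bonds along the chain from an amide-type nitrogen and a carbonyl carbon). For the measured compounds named here, no measured step exchanges an acid for a sulfur-bearing group, so only indirect hints exist: the steps ending in compound 3 show that the shortest acid chain gave the lowest number, and both compounds without that shortest acid chain gave higher numbers. Compound 4 is therefore expected to move upward from compound 3 by a number 13.4 percentage points higher from compound 3 to compound 4 (beyond the scatter), beyond the scatter but not by a large margin. Compound 4 is estimated at 25%, with a range from 10% to 42%.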

Compound 4, a percentage reported as activity, at one dose (the size of the read-out at that dose, not a potency): 4.14%
Estimate against measurement, compound 4: 20.9 percentage points above; measured number outside the range, below it.
By their numbers in this assay, from the lowest: compounds 4 and 3 (each within the scatter of the next); then compounds 1 and 2 (each within the scatter of the next).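

In this assay the change from carboxy to (methylsulfanyl)methyl gives a number 7.5 percentage points lower from compound 3 to compound 4 (within the scatter); at this position, a low number therefore occurs with or without the second acid group. The side chain with methylsulfanyl does not match the other two either, giving a number 25.4 percentage points lower from compound 2 to compound 4 (beyond the scatter) and a number 19.9 percentage points lower from compound 1 to compound 4 (beyond the scatter). Nothing measured here explains these differences.

Open, on these data alone, is how an amine or a phenyl group at this position would compare. So is whether a longer chain carrying methylsulfanyl would keep the same number.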